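Hydroxy in place of amino on a shared core

The source may report more compounds than this note shows. Statements on the series, on what has been measured and on what is new or still open speak of the compounds shown alone.

Compound 1 `O=c1ccn(COC(CO)CO)c(=O)[nH]1`, compound 2 `Cc1ccc(S(=O)(=O)Nc2ccn(C)c(=O)n2)cc1` and compound 3 `Nc1cn(COC(CO)CO)c(=O)[nH]c1=O` were all examined in a functional assay on MCF7 cells (Homo sapiens) for inhibition, read by MTT assay, with a stated time of 72 h; a higher number here means a weaker inhibitor, a lower number a stronger inhibitor. In this assay compound 1 gives > 100000 nM, which is a limit of the assay and not a number. Compound 2 gives > 100000 nM, likewise a limit. Compound 3 gives > 100000 nM, again a limit, so where compound 3 stands is known only as a limit, in line with the limit of > 100000 nM in this assay, at which 3 of the 3 values shown sit. Within the data shown here, the single step between measured compounds, a step that the two limits leave unreadable from compound 1 to compound 3, therefore cannot be sized. Compound 4 `O=c1[nH]c(=O)n(COC(CO)CO)cc1O` differs from compound 3 by hydroxy in place of amino on an aromatic carbon. Among the measured compounds shown here, the only measured step that bears on this position, a step that the two limits leave unreadable from compound 1 to compound 3, gives no readable size, so nothing beyond the scatter can be expected in this assay, and the expected step is a step that the limit leaves unreadable from compound 3 to compound 4. Compound 4 is accordingly expected to give about 150000 nM, in a range from 40000 nM to 600000 nM, most probably reported once more only as a limit.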

Compound 4, half-maximal inhibitory concentration: > 100000 nM
Compound 4 was reported as a limit; the forecaster's own chance of this, stated with the estimate: 85%; the middle value does not contradict the limit.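

No step can be read among compound 1, compound 3 and compound 4, as all of them stand only at a limit: the limit of > 100000 nM in this assay, at which 4 of the 4 values shown sit. The compounds shown leave open whether hydrogen, amino and hydroxy on this aromatic carbon differ at all in this assay.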